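The source may report more compounds than this note shows. Statements on the series, on what has been measured and on what is new or still open speak of the compounds shown alone.

Series notes. Going by the values given here, compound 1 `Cc1ccc(-c2cs/c(=N/NC(=O)CSc3nncn3C)n2-c2ccccc2)cc1` is the only member with a number: in a functional assay on C6 cells (Rattus norvegicus) for cytotoxicity, read by MTT assay, with a stated time of 24 h (a lower number here means a stronger inhibitor, a higher number a weaker inhibitor), compound 1 gives 56 ug/mL. Compound 2 `Cc1nnc(SCC(=O)N/N=c2/scc(-c3ccc(C#N)cc3)n2-c2ccccc2)s1` stands without a result; in this assay compound 2 gives "not determined" (no result reported), so no footing exists for it. Compound 3 `Cc1ccc(-c2cs/c(=N/NC(=O)CSc3nnc(C)s3)n2-c2ccccc2)cc1` differs from compound 2 by methyl in place of cyano on an aromatic carbon. Among the compounds with values here, no measured step covers this change, so no size or direction beyond the scatter is assumed. For compound 3 in this assay a value near 60 ug/mL is expected, within 25 ug/mL to 150 ug/mL, because compound 1 with the same 4-methylphenyl group gives 56 ug/mL.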

Compound 3, half-maximal inhibitory concentration: 25.3 ug/mL
Compound 3: middle estimate off by 2.4-fold (0.38 log units), on the high side; low and high end bracket the measured number.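

In this assay, the group on the sulfur proves able to move the read-out: 5-methyl-1,3,4-thiadiazol-2-yl in place of 4-methyl-4H-1,2,4-triazol-3-yl gives a 2.2-fold lower number from compound 1 to compound 3 (0.35 log units; beyond the scatter) with the 4-methylphenyl group unchanged. Going by these compounds alone, this is the only readable step so far, and it rests on a single pair. No available evidence bears on the reason for this difference.

Going by these compounds, the effect of 4-cyanophenyl against 4-methylphenyl stays open, with no value for compound 2 to compare. So does the outcome of an amine or a carboxylic acid in place of that methyl.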